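The source may report more compounds than this note shows. Statements on the series, on what has been measured and on what is new or still open speak of the compounds shown alone.

Compound 2, `COc1cc(-c2ccnc3cc(-c4c[nH]c5ccccc45)nn23)cc(OC)c1OC`, holds the lowest number of the three compounds measured in a functional assay on A549 cells (Homo sapiens) for inhibition, read by CCK-8 assay, with a stated time of 48 h; a lower number here means a stronger inhibitor, a higher number a weaker inhibitor: compound 2 gives 29 nM. The nearest measured compound is compound 3, `COc1cc(-c2ccnc3cc(-c4cn(C(=O)OC(C)(C)C)c5ccccc45)nn23)cc(OC)c1OC`, which gives 2070 nM; the step of a 71-fold higher number from compound 2 to compound 3 (1.85 log units; beyond the scatter) came with tert-butoxycarbonyl in place of hydrogen on an aromatic nitrogen. The furthest is compound 1, `Cn1ccc2cc(-c3cc4nccc(-c5ccc(F)cc5)n4n3)ccc21`, which gives 3520 nM and differs from compound 2 in more than one place, so its values are reported only side by side with those of compound 2.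

The unmeasured compound 4, `COc1cc(-c2ccnc3cc(-c4cccc(C)c4)nn23)cc(OC)c1OC`, differs from compound 2 as follows: 3-methylphenyl in place of 1H-indol-3-yl on an aromatic carbon. Within the data shown here, no measured step matches this change exactly. Among the measured compounds shown here, the one step that bears on it, a 71-fold higher number from compound 2 to compound 3 (1.85 log units; beyond the scatter), altered the same indole part of compound 2 and was large and upward; compound 1, with its changed indole, also sits far above compound 2. Compound 4 is therefore expected to give a clearly higher number in this assay, with an estimated step of a 24-fold higher number from compound 2 to compound 4 (1.38 log units; beyond the scatter). The estimate for compound 4 is 700 nM, in the range 150 nM to 3500 nM.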

Compound 4, half-maximal inhibitory concentration: 5730 nM
Compound 4: middle estimate off by 8.2-fold (0.91 log units), on the low side; the whole stated range lies below it.
By their numbers in this assay, from the lowest: compound 2; then compounds 3, 1 and 4 (each within the scatter of the next, the first and the last beyond it).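

In this assay, the earlier step at this part of compound 2, a 71-fold higher number from compound 2 to compound 3 (1.85 log units; beyond the scatter), kept the 1H-indol-3-yl and capped only its nitrogen, whereas 3-methylphenyl replaces the whole group and gives a 200-fold higher number from compound 2 to compound 4 (2.30 log units; beyond the scatter). The low number of compound 2 is therefore lost with either single change, and in both compound 3 and compound 4 the hydrogen-bond donor of the 1H-indol-3-yl is gone. Compound 4 loses that donor, the nitrogen and the five-membered ring in one change, so the compounds cannot separate their contributions, and no evidence is available that explains the rise.

From the compounds shown here alone, it remains open whether a phenyl carrying an amine or a hydroxyl group in place of the methyl would restore a low number. A 1H-indol-3-yl with a methyl on its nitrogen would also test whether the large rise with compound 3 depends on the size of the tert-butoxycarbonyl group.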